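A few compounds are considered here, and "the series" means these few. Any claim that something is new, unique, unknown or untested is made for them only; others in the source may bear on it.

In a functional assay on M21 cells (Homo sapiens) for inhibition, read by sulforhodamine B assay, with a stated time of 48 h (on this read-out lower numbers stand for stronger inhibition of growth and higher numbers for weaker inhibition of growth), compound 1 (`c1cc(NC2=NCCO2)cc(OC2CCCCCC2)c1`) gives 14400 nM, compound 2 (`O=C(CCl)NC(=O)Nc1cccc(OC2CCCC2)c1`) gives 3500 nM and compound 3 (`O=C(CCl)NC(=O)Nc1cccc(OC2CCCCC2)c1`) gives 2700 nM. Compound 2 and compound 3 lie within the scatter of each other at the low end of these numbers, and the number of compound 1 stands beyond the scatter from that of compound 3.

Compound 4 (`O=C(CCl)NC(=O)Nc1cccc(OC2CCCCCC2)c1`) has not yet been measured. It carries cycloheptyl in place of cyclohexyl on an oxygen on an aromatic ring.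

For the measured compounds named here, one measured step bears directly on this change, the swap of cyclopentyl for cyclohexyl at the same place, which gave a 1.3-fold lower number from compound 2 to compound 3 (0.11 log units; within the scatter). Going by the values given here, compound 1 also carries cycloheptyl, but its core differs, so it offers no matching step. On the evidence of that single small step, no shift beyond the scatter is expected in this assay. The expected step is a 1.1-fold lower number from compound 3 to compound 4 (0.05 log units; within the scatter). For compound 4 the estimated value is 2400 nM, with an expected range from 1100 nM to 5000 nM.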

Compound 4, concentration for 50% growth inhibition: 4200 nM
For compound 4 the middle estimate is 1.8-fold (0.24 log units) below the measured one; measured number inside the range.
By their numbers in this assay, from the lowest: compounds 3, 2 and 4 (each within the scatter of the next); then compound 1.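

In this assay, cycloheptyl in place of cyclohexyl on the oxygen gives a 1.6-fold higher number from compound 3 to compound 4 (0.19 log units; within the scatter), and cycloheptyl in place of cyclopentyl gives a 1.2-fold higher number from compound 2 to compound 4 (0.08 log units; within the scatter), so all three rings now tested at this place leave the numbers within the scatter of one another. With cycloheptyl held constant, the change on the nitrogen on an aromatic ring gives a 3.4-fold lower number from compound 1 to compound 4 (0.54 log units; beyond the scatter), the only step here beyond the scatter, so among these compounds the group at that nitrogen moves the number more than the ring on the oxygen does. No measurement shown accounts for either result.

The compounds shown leave open whether an open chain such as n-hexyl, or a benzyl group, on the same oxygen would stay within the scatter of these rings. They also leave open whether a cyclobutyl ring would do so.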